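The compounds below may be only part of what the source reports. "The series", "measured", "known", "first", "only" and "open" are said of these compounds alone.

Compound 1 `COc1cc(OC)c(/C=C(\C(=O)c2ccc(Br)cc2)S(=O)(=O)Cc2ccc(Cl)cc2)c(OC)c1` gives 25000 nM; compound 2 `COc1cc(OC)c(/C=C(/SCc2ccc(F)cc2)C(=O)c2ccc(Br)cc2)c(OC)c1` gives 1000 nM; compound 3 `CN(C)c1ccc(/C=C(/SCc2ccc(F)cc2)C(=O)c2ccc(C(=O)O)cc2)cc1` gives 10000 nM.

All three were tested in a functional assay on DU-145 cells (Homo sapiens) for inhibition, read by trypan blue exclusion, with a stated time of 96 h; on this read-out higher numbers stand for weaker inhibition of growth and lower numbers for stronger inhibition of growth. Compound 4 `CN(C)c1ccc(/C=C(\C(=O)c2ccc(C(=O)O)cc2)S(=O)(=O)Cc2ccc(Cl)cc2)cc1` has not yet been tested there. Compound 4 arises from compound 3 by a single change: (4-chlorobenzyl)sulfonyl in place of (4-fluorobenzyl)sulfanyl on a double-bonded chain carbon bound to a carbonyl carbon and a double-bonded chain carbon. The same change, ((4-chlorobenzyl)sulfonyl in place of (4-fluorobenzyl)sulfanyl on a double-bonded chain carbon bound to a carbonyl carbon and a double-bonded chain carbon), turns compound 2 into compound 1, and that step was a 25-fold higher number from compound 2 to compound 1 (1.40 log units; beyond the scatter). The difference between the core of compound 2 and the core of compound 3 is not broken down here. Since the change sits at the same place in both pairs, a step of similar size is expected from compound 3 to compound 4, namely a 15-fold higher number from compound 3 to compound 4 (1.18 log units; beyond the scatter), an expectation that rests on a 25-fold higher number from compound 2 to compound 1 (1.40 log units; beyond the scatter). Compound 4 is therefore estimated to give about 150000 nM in this assay, with an expected range from 40000 nM to 500000 nM.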

Compound 4, concentration for 50% growth inhibition: > 100000 nM
Compound 4: a limit, no number (the forecaster's own chance of this, stated with the estimate: 40%); the middle value does not contradict the limit.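

In this assay, putting (4-chlorobenzyl)sulfonyl in place of (4-fluorobenzyl)sulfanyl also weakens growth inhibition on the second core, with an at least 10-fold higher number from compound 3 to compound 4 (1.00 log units; beyond the scatter). The direction of the change therefore carries over between these two pairs, but whether its size does stays unsettled: the same change on two cores in this assay, a 25-fold higher number (1.40 log units; beyond the scatter) from compound 2 to compound 1 and an at least 10-fold higher number (1.00 log units; beyond the scatter) from compound 3 to compound 4; the limit leaves it open whether they differ Compound 4 stands at a limit of the assay, not at a number: the limit of > 100000 nM in this assay, at which 1 of the 4 values shown sits.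

The change swaps the fluorine for a chlorine and the sulfanyl for a sulfonyl in one step, and the compounds shown do not separate the two. As far as these compounds go, a (4-fluorobenzyl)sulfonyl or a (4-chlorobenzyl)sulfanyl group at this place would be needed to tell them apart, and cores beyond these two also remain open.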